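Ring size and stereochemistry of an alkynyl-pyridine ether series

The source may hold more compounds than are shown below. What is called first, only, known or untested is meant among the compounds shown, and "the series" means these compounds.

Compound 1 `CCCCC#Cc1cncc(OC[C@@H]2CCN2)c1`: 0.1 nM
Compound 2 `CCCCC#Cc1cncc(OC[C@@H]2CCCN2)c1`: 1.2 nM
Compound 3 `CCCCC#Cc1cncc(OC[C@H]2CCCN2)c1`: 0.49 nM

In an assay on HEK293 cells for displacement of a labelled ligand from Neuronal acetylcholine receptor; alpha4/beta2 (Rattus norvegicus), read by scintillation counting (on this read-out lower numbers stand for stronger inhibition and higher numbers for weaker inhibition), compound 1 gives 0.1 nM, the lowest of the three numbers; compound 3 follows at a 4.9-fold higher number from compound 1 to compound 3 (0.69 log units; beyond the scatter), and compound 2 lies furthest off, at a 12-fold higher number from compound 1 to compound 2 (1.08 log units; beyond the scatter). Both of those steps replace azetidin-2-yl with pyrrolidin-2-yl on a saturated chain carbon bound to an oxygen on an aromatic ring. Between the two pyrrolidine compounds there is a 2.4-fold lower number from compound 2 to compound 3 (0.39 log units; beyond the scatter), which can be laid only to the fact that compounds 2 and 3 differ only in the configuration as drawn.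

Compound 4 `CCCCC#Cc1cncc(OC[C@H]2CCN2)c1` is not yet measured. It differs from compound 1 in this way: the two compounds have the same atoms and bonds and differ only in configuration as drawn: 1 of 1 stereo elements differ; a stereocentre at a saturated ring carbon is drawn S in compound 1 and R in compound 4. For the measured compounds named here, the only measured step that bears on it is the one from compound 2 to compound 3, where the same change of drawn configuration on the saturated ring carbon gave a modest lowering of the number. The step from compound 1 to compound 4 is therefore expected to be of similar size and in the same direction, a 1.7-fold lower number from compound 1 to compound 4 (0.22 log units; within the scatter). For compound 4 the estimated value in this assay is 0.06 nM, with a range from 0.015 nM to 0.3 nM.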

Compound 4, inhibition constant: 0.5 nM
Compound 4: middle estimate off by 8.3-fold (0.92 log units), on the low side, outside the stated range (above it).
By their numbers in this assay, from the lowest: compound 1; then compounds 3 and 4 (each within the scatter of the next); then compound 2.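

In this assay, the change from S to R at the saturated ring carbon gives a 5.0-fold higher number from compound 1 to compound 4 (0.70 log units; beyond the scatter), opposite in direction to a 2.4-fold lower number from compound 2 to compound 3 (0.39 log units; beyond the scatter), so the outcome of this change depends on the ring that carries it, and the new step can be laid only to configuration: the fact that compounds 1 and 4 differ only in the configuration as drawn The ring swap depends on configuration in turn: among the R compounds, azetidin-2-yl in place of pyrrolidin-2-yl gives a 1.0-fold higher number from compound 3 to compound 4 (0.01 log units; within the scatter), whereas the S compounds are separated by a 12-fold higher number from compound 1 to compound 2 (1.08 log units; beyond the scatter). The remaining step, a 2.4-fold lower number from compound 2 to compound 4 (0.38 log units; beyond the scatter), combines the ring swap with the change of configuration, so it cannot be assigned to either alone.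

The compounds shown leave open whether this interplay of ring and configuration extends to a piperidin-2-yl group. They also leave open whether it survives a longer chain on the alkyne.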